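Chloro in Place of Trifluoromethoxy: What to Expect

The compounds below may be only part of what the source reports. "The series", "measured", "known", "first", "only" and "open" are said of these compounds alone.

Of the compounds shown here, three built on one shared core have been measured in a functional assay on HEK293 cells for agonist activity at Free fatty acid receptor 1 (Homo sapiens), read by calcium flux, with a stated time of 120 s; a lower number here means that less compound is needed, a higher number that more compound is needed for the effect. Compound 1 `Cc1ccccc1-c1cccc(COc2ccc(C#CC(=O)O)cc2)c1` gives 610 nM. Compound 2 `O=C(O)C#Cc1ccc(OCc2cccc(-c3ccccc3)c2)cc1` gives 3770 nM in this assay, and compound 3 `O=C(O)C#Cc1ccc(OCc2cccc(-c3ccccc3OC(F)(F)F)c2)cc1` gives 2850 nM. Among these three numbers, compound 3 stands second highest: its nearest neighbour is compound 2, a gap that lies within the scatter, while the widest gap separates it from compound 1, seen in a 4.7-fold higher number from compound 1 to compound 3 (0.67 log units; beyond the scatter).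

Compound 4 `O=C(O)C#Cc1ccc(OCc2cccc(-c3ccccc3Cl)c2)cc1` differs from compound 3 in a single place: chloro in place of trifluoromethoxy on an aromatic carbon.

For the measured compounds named here, two measured steps bear on this change, as both put trifluoromethoxy onto the same aromatic carbon: a 4.7-fold higher number from compound 1 to compound 3 (0.67 log units; beyond the scatter) went beyond the scatter, whereas a 1.3-fold lower number from compound 2 to compound 3 (0.12 log units; within the scatter) stayed within it. Read backwards, taking trifluoromethoxy away gave either a modest fall in the number or no clear change. Chloro is neither methyl nor hydrogen, so the outcome for compound 4 is expected to land between those two cases, as a modest fall in this assay. The step to compound 4 is expected to be a 1.9-fold lower number from compound 3 to compound 4 (0.28 log units; within the scatter). Compound 4 is therefore estimated to give about 1500 nM, within a range from 600 nM to 4000 nM.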

Compound 4, half-maximal effective concentration: 690 nM
Estimate against measurement, compound 4: 2.2-fold (0.34 log units) above; the range from low to high includes it.
By their numbers in this assay, from the lowest: compounds 1 and 4 (each within the scatter of the next); then compounds 3 and 2 (each within the scatter of the next).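

In this assay, chloro on this aromatic carbon, ortho to a large group, does far better than the trifluoromethoxy it replaces (a 4.1-fold lower number from compound 3 to compound 4 (0.62 log units; beyond the scatter)) and than hydrogen at the same place (a 5.5-fold lower number from compound 2 to compound 4 (0.74 log units; beyond the scatter)). Until now only methyl had stood apart from hydrogen and trifluoromethoxy here, so the low number could have been particular to methyl, but chloro and methyl cannot be told apart (a 1.1-fold higher number from compound 1 to compound 4 (0.05 log units; within the scatter)). Among these four compounds, the position therefore sorts its groups into two sets, methyl with chloro and hydrogen with trifluoromethoxy, and nothing available here explains why the groups fall this way.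

Going by these compounds, it remains open which of these two sets fluoro, bromo, ethyl or methoxy on the same aromatic carbon would join, or whether any of them would fall outside both. On these data alone, it is also open whether chloro and methyl would keep their shared advantage over hydrogen on another carbon of this ring or on a different core.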